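The source may report more compounds than this note shows. Statements on the series, on what has been measured and on what is new or still open speak of the compounds shown alone.

Of the compounds shown here, three have been measured, each built on a shared core of two joined rings. In an assay on COS-7 cells for inhibition of patatin-like phospholipase domain-containing protein 2 (Mus musculus), tested at 200 uM (a lower number here means less inhibition, a higher number more inhibition at the concentration tested (going by the name of the read-out)), compound 1 `CCOC(=O)c1cccc(-c2ccc(OCC)cc2)n1` gives 79%. Compound 2 `CCOC(=O)c1cccc(-c2ccc([N+](=O)[O-])cc2)c1` gives 63% in this assay, and compound 3 `CCOc1ccc(-c2cccc(S(=O)(=O)N(C)C)c2)cc1` gives 63%. Compound 3 therefore stands level with compound 2 at the digits shown, the two together the lowest of the three numbers, while compound 1 sits higher by a gap beyond the usual scatter.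

Compound 4 `CCNC(=O)c1cccc(-c2ccc(OCC)cc2)c1` differs from compound 3 in one place: ethylcarbamoyl in place of dimethylsulfamoyl on an aromatic carbon. Among the compounds with values here, no measured pair shows this change, so the expectation rests on the three numbers alone. A small upward step, or none beyond the scatter, is expected, a number 5 percentage points higher from compound 3 to compound 4 (within the scatter). For compound 4 the estimate in this assay is 68%, within 50% to 85%.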

Compound 4, a percentage reported as inhibition, at one concentration (the size of the read-out at that concentration, not a potency): 62%
For compound 4 the middle estimate is 6 percentage points above the measured one; the range from low to high includes it.
By their numbers in this assay, from the lowest: compounds 4, 2 and 3 (each within the scatter of the next); then compound 1.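

Putting ethylcarbamoyl in place of dimethylsulfamoyl on this aromatic carbon gives, in this assay, a number 1 percentage points lower from compound 3 to compound 4 (within the scatter). The two groups differ in their atoms, and only ethylcarbamoyl carries a hydrogen-bond donor, yet this read-out at a single concentration does not separate them. Nothing measured here offers an explanation for this.

As far as these compounds go, whether an amine, a carboxylic acid or a longer chain at this position would move the number beyond the scatter remains open. So does whether this exchange would give the same result on a different core.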